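Compound 3 and the butyl swap

This account rests on a few compounds, and the source may have more. Where it says the series, first, only, none or still open, it means among the compounds named here.

Compound 1 `COc1ccc([C@@H]2CC(=O)c3cc(CC=C(C)C)c(OC)cc3O2)cc1`: 65%
Compound 2 `COc1cc2c(cc1CC=C(C)C)C(=O)C[C@@H](c1ccc(Oc3cccc([N+](=O)[O-])c3)cc1)O2`: 53%

In a functional assay on MCF7 cells (Homo sapiens) for inhibition, read by sulforhodamine B assay, with a stated time of 48 h, tested at 50 uM (a higher number here means more inhibition of growth at the concentration tested, a lower number less inhibition of growth), compound 2 gives 53%, the lower of the two numbers, and it sits under compound 1 by a gap beyond the scatter. The next compound, compound 3 `CCCCOc1ccc([C@@H]2CC(=O)c3cc(CC=C(C)C)c(OC)cc3O2)cc1`, keeps the shared core and changes one group: butyl in place of 3-nitrophenyl on an oxygen on an aromatic ring.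

Among the measured compounds shown here, only one measured step bears on this: a number 12 percentage points lower from compound 1 to compound 2 (beyond the scatter), with 3-nitrophenyl in place of methyl on that oxygen. Butyl, like methyl, has no ring, so a partial return toward compound 1 at 65% is expected, though one step is thin evidence. The estimated change is a number 7 percentage points higher from compound 2 to compound 3 (within the scatter), small and upward. For compound 3 the expected value in this assay is 60%, with an estimated range of 47% to 73%.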

Compound 3, percent growth inhibition at one concentration: 57%
Estimate against measurement, compound 3: 3 percentage points above, and the stated range covers the measured number.
By their numbers in this assay, from the lowest: compounds 2, 3 and 1 (each within the scatter of the next, the first and the last beyond it).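

In this assay, butyl on this oxygen gives a number 4 percentage points higher from compound 2 to compound 3 (within the scatter), while the same chain set against the methyl of compound 1 gives a number 8 percentage points lower from compound 1 to compound 3 (within the scatter), so neither step separates compound 3 from its neighbour. Compound 1 and compound 2 do differ beyond the scatter, yet compound 3, with an open chain and no ring, falls within the scatter of both, so this single change cannot show whether butyl behaves more like methyl or more like 3-nitrophenyl. Nothing measured here explains these numbers.

Going by these compounds, whether a longer chain, an amine or a carboxylic acid on this oxygen would move the number remains open. So does whether the gap between compound 1 and compound 2 belongs to the aromatic ring of the 3-nitrophenyl or to its nitro group, which a plain phenyl would help to separate.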